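A few compounds are considered here, and "the series" means these few. Any claim that something is new, unique, unknown or untested is made for them only; others in the source may bear on it.

Compound 1 `Cn1c(-c2ccc(NC(=O)CSc3nc4cc(Cl)ccc4o3)cc2)nc(-c2ccccc2)c1-c1ccccc1` gives 79.6% in a functional assay on HT-29 cells (Homo sapiens) for cytotoxicity, read by MTT assay, with a stated time of 24 h, tested at 80 ug/mL; on this read-out lower numbers stand for a weaker effect and higher numbers for a stronger effect at the one concentration tested.
Compound 2 `Cn1nnnc1SCC(=O)Nc1ccc(-c2nc(-c3ccccc3)c(-c3ccccc3)n2C)cc1` gives 89% in this assay.

For the measured compounds named here, compound 2 holds the higher of the two numbers, and the only measured step, a number 9.4 percentage points higher from compound 1 to compound 2 (within the scatter), lies within the scatter, so the two compounds cannot be told apart on this read-out. Compound 3 `CN1CCN(CC(=O)Nc2ccc(-c3nc(-c4ccccc4)c(-c4ccccc4)n3C)cc2)CC1` differs from compound 2 in one place: 4-methylpiperazin-1-yl in place of (1-methyl-1H-tetrazol-5-yl)sulfanyl on a saturated chain carbon bound to a carbonyl carbon. Going by the values given here, the single measured step swaps one ring for another while the sulfur stays in place; no measured step removes the sulfur-bearing group altogether, so that step gives only weak guidance here. Given that the one known change left the number unchanged beyond the scatter, a step of a number 11 percentage points lower from compound 2 to compound 3 (beyond the scatter) is expected for compound 3, with wide uncertainty. Compound 3 is therefore estimated at 78%, in a range from 50% to 95%.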

Compound 3, a percentage reported as activity, at one concentration (the size of the read-out at that concentration, not a potency): 53.1%
For compound 3 the middle estimate is 24.9 percentage points above the measured one; the measured number falls inside the stated range.
By their numbers in this assay, from the lowest: compound 3; then compounds 1 and 2 (each within the scatter of the next).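

Until now only the ring on the sulfur had changed, and that change stayed within the scatter. Replacing the whole sulfur-bearing group on the saturated chain carbon bound to a carbonyl carbon with 4-methylpiperazin-1-yl gives, in this assay, a number 35.9 percentage points lower from compound 2 to compound 3 (beyond the scatter) and also a number 26.5 percentage points lower from compound 1 to compound 3 (beyond the scatter), so this position does respond to what it carries, even though (1-methyl-1H-tetrazol-5-yl)sulfanyl and 4-methylpiperazin-1-yl have the same count of heavy atoms. Nothing measured here accounts for this drop.

Still open, going by these compounds, is whether the drop follows from losing the sulfur, from losing the aromatic ring, or from bringing in the ring nitrogens of 4-methylpiperazin-1-yl. A piperidin-1-yl or dimethylamino group on the same carbon would help separate these possibilities.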